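Removing a Methyl Group: What Compound 4 May Tolerate

This account rests on a few compounds, and the source may have more. Where it says the series, first, only, none or still open, it means among the compounds named here.

Measured compounds:
compound 1, `CC(C)CCn1c(CN2C(=O)C(C)(O)c3ccccc32)nc2ccccc21`: 101000 nM
compound 2, `N#CCCCCn1c(CN2C(=O)CS(=O)(=O)c3ccccc32)nc2ccccc21`: > 270000 nM
compound 3, `N#CCCCn1c(CN2C(=O)N(C3CC3)S(=O)(=O)c3ccccc32)nc2ccccc21`: > 244000 nM

All three were tested in an ADME assay on HEp-2 cells (Homo sapiens) for cytotoxicity; a lower number here means that less compound is tolerated, a higher number that more compound is tolerated. Going by the values given here, compound 1 is the only one with an actual number, giving 101000 nM in this assay. For compound 2 the result is a limit of the assay, not a number: it sits at the limit of > 270000 nM in this assay, at which 1 of the 3 values shown sits. For compound 3 the result is also a limit, (the limit of > 244000 nM in this assay, at which 1 of the 3 values shown sits). So compound 1 stands alone as the one measurable point, and the other two simply tell that nothing was seen up to the limit.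

Compound 4, `CC(C)CCn1c(CN2C(=O)C(O)c3ccccc32)nc2ccccc21`, differs from compound 1 in a single place: hydrogen in place of methyl on a saturated ring carbon. The shared core and the side chain on the ring nitrogen stay the same.

Among the compounds with values here, no step between two measured compounds is available, so there is nothing to compare this change against. A methyl group lost on a saturated ring carbon is a small change, and the expectation is a step of no size beyond the scatter, in neither direction, from compound 1 to compound 4: the expected step is a 1.2-fold higher number from compound 1 to compound 4 (0.07 log units; within the scatter). In this assay compound 4 is therefore estimated at 120000 nM, with a range from 50000 nM to 300000 nM.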

Compound 4, half-maximal cytotoxic concentration: 3310 nM
The estimate for compound 4 lay 36-fold (1.56 log units) above the measured number; measured number outside the range, below it.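

In this assay, replacing the methyl group on the saturated ring carbon with hydrogen gives a 31-fold lower number from compound 1 to compound 4 (1.48 log units; beyond the scatter). Going by these compounds alone, this is the first step between two measured compounds that differ in one place, and it shows that this position, two ring bonds from the ring nitrogen, is sensitive to even a small change. The loss of a single carbon, with the shared core and the side chain on the ring nitrogen left as they were, is enough to move the number by far more than the usual scatter, although this finding rests on one pair of compounds.

No result shown bears on why the step is so large. Also open, as far as these compounds go, is whether an ethyl group on the same ring carbon would give a number closer to that of compound 1 or compound 4, and whether the step would keep its size with a different side chain on the ring nitrogen, such as a longer chain ending in an amine.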